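The compounds below may be only part of what the source reports. "The series", "measured", "known", "first", "only" and "open" are said of these compounds alone.

Measured so far:
compound 1 `N#CC1=C(N)Oc2c(c3nc4ccccc4nc3c3ccccc23)C12C(=O)N(Cc1cnnn1-c1cccc(Cl)c1)c1ccccc12`: 32600 nM
compound 2 `N#CC1=C(N)Oc2c(c3nc4ccccc4nc3c3ccccc23)C12C(=O)N(Cc1cnnn1-c1cccc(S(N)(=O)=O)c1)c1ccccc12`: 44200 nM

Among the compounds with values here, in a functional assay on A549 cells (Homo sapiens) for antiproliferative activity, read by MTT assay, with a stated time of 48 h (a higher number here means a weaker inhibitor, a lower number a stronger inhibitor), compound 2 gives the highest of the two numbers, the other being compound 1; the single step between them is a 1.4-fold higher number from compound 1 to compound 2 (0.13 log units; within the scatter). Compound 3 `Cc1ccc(-n2nncc2CN2C(=O)C3(C(C#N)=C(N)Oc4c3c3nc5ccccc5nc3c3ccccc43)c3ccccc32)cc1Cl` differs from compound 2 by 3-chloro-4-methylphenyl in place of 3-sulfamoylphenyl on an aromatic nitrogen. Within the data shown here, the only step that bears on it is the one from compound 1 to compound 2, which exchanged a group on the same aromatic nitrogen and stayed within the scatter, so no shift beyond the scatter is expected here; the expected step is a 1.4-fold lower number from compound 2 to compound 3 (0.14 log units; within the scatter). Compound 3 is estimated at 32000 nM in this assay, with a range from 12000 nM to 85000 nM.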

Compound 3, half-maximal inhibitory concentration: > 50000 nM
Compound 3 ended at the assay's limit; the forecaster's own chance of this, stated with the estimate: 10%; middle value at least 1.5-fold (0.19 log units) from the limit.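

In this assay compound 3 gives > 50000 nM, which is a limit of the assay and not a number. The exchange on the aromatic nitrogen reads as an at least 1.1-fold higher number from compound 2 to compound 3 (0.05 log units; that floor lies within the scatter), and methyl in place of hydrogen on an aromatic carbon reads as an at least 1.5-fold higher number from compound 1 to compound 3 (0.18 log units; that floor lies within the scatter). Both are floors only, so neither step establishes a change beyond the scatter, and the methyl adds no measurable shift at this position.

Still open, on these data alone, is how an amine or a carboxylic acid on this phenyl ring would read in this assay. Also open, as far as these compounds go, is the effect of replacing the phenyl on the aromatic nitrogen with a simple alkyl chain.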